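Shortening the linker and unmasking the piperazine in compound 1

This account rests on a few compounds, and the source may have more. Where it says the series, first, only, none or still open, it means among the compounds named here.

Compound 1 `CN1CCN(CCCN(C[C@H]2Cc3ccccc3CN2)[C@H]2CCCc3cccnc32)CC1` is the reference point of this small set. In a functional assay on CCRF-CEM cells for antagonist activity at C-X-C chemokine receptor type 4 (Homo sapiens), read by calcium flux, with stated times of 25 min and 90 s (a lower number here means a stronger inhibitor, a higher number a weaker inhibitor), compound 1 gives 125 nM, the lowest of the two numbers to hand. Compound 2 `c1cnc2c(c1)CN[C@H](CN(CCCN1CCNCC1)[C@H]1CCCc3cccnc31)C2` gives 2640 nM in this assay, a markedly higher number; compound 2 differs from compound 1 in more than one place, so the values alone are all that can be read from the pair.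

Compound 3 `c1ccc2c(c1)CN[C@@H](CN(CCN1CCNCC1)[C@H]1CCCc3cccnc31)C2` has not yet been measured in this assay. Relative to compound 1 the change is piperazin-1-yl in place of (4-methylpiperazin-1-yl)methyl on a saturated chain carbon, two bonds along the chain from an amine nitrogen. Going by the values given here, no single-point step between measured compounds is available to calibrate it, but the direction of the pair of values above suggests a loss rather than a gain. The expected step is a 4.8-fold higher number from compound 1 to compound 3 (0.68 log units; beyond the scatter), a weakening beyond the scatter. Compound 3 is therefore estimated at 600 nM in this assay, with a likely range from 150 nM to 2500 nM.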

Compound 3, half-maximal inhibitory concentration: 553 nM
Compound 3: middle estimate off by 1.1-fold (0.04 log units), on the high side; measured number inside the range.
By their numbers in this assay, from the lowest: compound 1; then compound 3; then compound 2.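

In this assay, going by these compounds alone, piperazin-1-yl in place of (4-methylpiperazin-1-yl)methyl gives a 4.4-fold higher number from compound 1 to compound 3 (0.65 log units; beyond the scatter) and provides the first single-place reading on this saturated chain carbon, two bonds along the chain from an amine nitrogen. Cut one bond further out, the same difference reads 3-(4-methylpiperazin-1-yl)propyl to 2-(piperazin-1-yl)ethyl, so the shorter chain and the loss of the methyl group arrive together, and the step prices only the combined change. No supporting measurement bears on the origin of this weakening.

Going by these compounds, the separate contributions of chain length and the methyl group remain open, and 3-(piperazin-1-yl)propyl or 2-(4-methylpiperazin-1-yl)ethyl at this place would divide them. Also open, on these data alone, is how a longer chain, such as 4-(piperazin-1-yl)butyl, would read.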